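This account rests on a few compounds, and the source may have more. Where it says the series, first, only, none or still open, it means among the compounds named here.

Measured compounds:

Compound 1, `COc1cccc(C(=O)NCc2ccc(CNS(=O)(=O)c3ccc(C)cc3)cc2)c1`: 10 nM
Compound 2, `Cc1ccc(S(=O)(=O)NCc2ccc(CNC(=O)c3ccncc3)cc2)cc1`: 10 nM

Both compounds share one core and differ only in the group attached to a carbonyl carbon. In an assay on MDA-MB-231 cells for binding affinity to C-X-C chemokine receptor type 4 (Homo sapiens), read by immunofluorescence and microscopy, with stated times of 10 min and 30 min (a higher number here means that more compound is needed for the effect, a lower number that less compound is needed), compound 1 gives 10 nM, and in the same assay compound 2 gives 10 nM. Going by the values given here, compound 2 therefore stands level with compound 1: the single step from one to the other, no change at the digits printed from compound 1 to compound 2 (within the scatter), stays within the scatter of the assay.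

The next compound, compound 3, `Cc1ccc(S(=O)(=O)NCc2ccc(CNC(=O)c3ccccc3F)cc2)cc1`, arises from compound 2 through one change: 2-fluorophenyl in place of pyridin-4-yl on a carbonyl carbon. One six-membered aromatic ring is thus traded for another at the same carbonyl carbon.

Among the compounds with values here, only one measured step bears on this change, the swap at that carbonyl carbon from compound 1 to compound 2, which read no change at the digits printed from compound 1 to compound 2 (within the scatter). That swap changed nothing beyond the scatter, so the expectation here is the same: no step beyond the scatter, which is what no change at the digits printed from compound 2 to compound 3 (within the scatter) expresses. Compound 3 is estimated at 10 nM in this assay, with a range from 4 nM to 30 nM.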

Compound 3, effective concentration (reported as EC, without a stated level of effect): 1000 nM
Compound 3: middle estimate off by 100-fold (2.00 log units), on the low side; measured number outside the range, above it.
By their numbers in this assay, from the lowest: compounds 1 and 2 (each within the scatter of the next); then compound 3.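

The group on the carbonyl carbon is not freely interchangeable: in this assay, 2-fluorophenyl in place of pyridin-4-yl gives a 100-fold higher number from compound 2 to compound 3 (2.00 log units; beyond the scatter), and 2-fluorophenyl in place of 3-methoxyphenyl gives a 100-fold higher number from compound 1 to compound 3 (2.00 log units; beyond the scatter). Going by these compounds alone, the earlier result, no change at the digits printed from compound 1 to compound 2 (within the scatter), therefore showed only that these two groups read alike, not that any six-membered aromatic ring is accepted here, since compound 3 also carries such a ring on the same carbonyl carbon and keeps the shared core. No available evidence accounts for this large step.

Three groups cannot settle whether the higher number goes with the fluorine itself or with where it sits on the ring, a question that plain phenyl and 3-fluorophenyl at this carbonyl carbon would address. Also open, going by these compounds, is whether a non-aromatic group there, such as cyclohexyl or a short chain ending in an amine, would read level with compound 1 and compound 2 or closer to compound 3.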